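The compounds below may be only part of what the source reports. "The series", "measured", "known", "first", "only" and "open" are said of these compounds alone.

In a functional assay on HCT-116 cells (Homo sapiens), read by MTT assay, with a stated time of 72 h (a higher number here means a weaker inhibitor, a lower number a stronger inhibitor), compound 2 `Nc1nc(N)c2c(-c3ccco3)cn([C@@H]3O[C@H](CO)[C@@H](O)[C@H]3O)c2n1` gives > 20000 nM, and this value is a limit of the assay, not a number. Its exact position is therefore unknown. Compound 1 `Cc1ncnc2c1c(-c1ccsc1)cn2[C@@H]1O[C@H](CO)[C@@H](O)[C@H]1O`, which has a different substitution on the shared core, gives a measured 1430 nM in this assay and already carries thiophen-3-yl. Compound 3 `Nc1nc(N)c2c(-c3ccsc3)cn([C@@H]3O[C@H](CO)[C@@H](O)[C@H]3O)c2n1` keeps the substitution of compound 2 and differs from it in a single place: thiophen-3-yl in place of furan-2-yl on an aromatic carbon. Going by the values given here, no measured pair isolates this exchange, so the expectation rests on thin ground. The presence of thiophen-3-yl in compound 1 at 1430 nM suggests some gain in strength, but the other differences in compound 1 keep that expectation modest. The expected step is small, an at least 1.3-fold lower number from compound 2 to compound 3 (0.12 log units; that floor lies within the scatter), toward a stronger inhibitor. For compound 3, the estimated value is 15000 nM, with an expected range of 4000 nM to 30000 nM.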

Compound 3, half-maximal inhibitory concentration: > 20000 nM
Compound 3 was reported as a limit; the forecaster's own chance of this, stated with the estimate: 50%; middle value at least 1.3-fold (0.12 log units) from the limit.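

In this assay compound 3 gives > 20000 nM, which is a limit of the assay and not a number. Going by these compounds alone, compound 2 sits at the same limit, so no step between compound 2 and compound 3 can be read. The compounds shown leave open whether thiophen-3-yl in place of furan-2-yl changes strength at all.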